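Aryl substitution on the shared core of compound 1

The source may hold more compounds than are shown below. What is called first, only, known or untested is meant among the compounds shown, and "the series" means these compounds.

Going by the values given here, compound 1, `CC(C)(C)C1=NN(c2cccc(F)c2)C(c2ccc(O)cc2)C1`, is the only member of this set with a number: in an assay on isolated protein for inhibition of protein kinase C zeta type (Homo sapiens), with a stated time of 4 min (a higher number here means a weaker inhibitor, a lower number a stronger inhibitor), compound 1 gives 2200 nM. Among the compounds with values here, compound 2, `CC(C)(C)C1=NN(c2ccccc2Cl)C(c2ccc(O)cc2)C1`, gives "not determined" (no result reported) in this assay, and compound 3, `Cc1ccc(N2N=C(C(C)(C)C)CC2c2ccc(O)cc2)c(C)c1`, gives "not determined" (no result reported), so no step between measured compounds can be stated. Compound 4, `CC(C)(C)C1=NN(c2ccc(F)c(Cl)c2)C(c2ccc(O)cc2)C1`, differs from compound 1 in one place: 3-chloro-4-fluorophenyl in place of 3-fluorophenyl on an amine nitrogen in a ring. Within the data shown here, with no measured step to lean on, the expectation for this change is a step within the usual scatter, leaning toward a slightly stronger inhibitor, which is a 1.5-fold lower number from compound 1 to compound 4 (0.17 log units; within the scatter) for compound 4. Compound 4 is therefore estimated at 1500 nM in this assay, with a range from 500 nM to 5000 nM.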

Compound 4, half-maximal inhibitory concentration: 900 nM
Estimate against measurement, compound 4: 1.7-fold (0.22 log units) above; the range from low to high includes it.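

Going by these compounds alone, the aryl group on the ring amine nitrogen gives the first readable step: 3-chloro-4-fluorophenyl in place of 3-fluorophenyl gives a 2.4-fold lower number from compound 1 to compound 4 (0.39 log units; beyond the scatter) in this assay. The aryl group at this position therefore affects the read-out, though the step is modest. No supporting data bear on the origin of this step.

Steps involving compound 2 and compound 3 cannot be read. Open questions are whether 3-chlorophenyl or 4-fluorophenyl alone would account for the step, and how a carboxylic acid or an amine on this aryl ring would read.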